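Trading a piperidine tail for a chloromethyl end

The source may hold more compounds than are shown below. What is called first, only, known or untested is meant among the compounds shown, and "the series" means these compounds.

Compound 2 `Cn1c(=O)c2[nH]c(-c3ccc(OCCC4CCNCC4)cc3)nc2n(C)c1=O` is the reference point here. Among the compounds with values here, in an assay on CHO cells for displacement of a labelled ligand from adenosine receptor A1 (Homo sapiens), read by scintillation counting, with a stated time of 3 h (a lower number here means a stronger inhibitor, a higher number a weaker inhibitor), compound 2 gives 1.33 nM, and this is the only number that has been obtained. Compound 1 `Cn1c(=O)c2[nH]c(Cc3ccc(OCCCCl)cc3)nc2n(C)c1=O` returns > 30 nM in this assay, which is a limit of the assay and not a number, so it is recorded as the limit of > 30 nM in this assay, at which 1 of the 2 values shown sits. Within the data shown here, compound 2 therefore stands alone as the single measured value, with nothing to rank it against.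

Compound 3 `Cn1c(=O)c2[nH]c(-c3ccc(OCCCCl)cc3)nc2n(C)c1=O` remains to be measured in this assay. It differs from compound 2 by chloromethyl in place of piperidin-4-yl on a saturated chain carbon, two bonds along the chain from an oxygen on an aromatic ring. Among the measured compounds shown here, no step between two measured compounds is available to calibrate this change, so the expectation rests only on the two structures and on the one number known. The step from compound 2 to compound 3 is expected to be a loss that goes beyond the usual scatter, a 23-fold higher number from compound 2 to compound 3 (1.35 log units; beyond the scatter). Compound 3 is estimated at 30 nM, within a range from 5 nM to 200 nM.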

Compound 3, inhibition constant: > 10 nM
Compound 3: only a limit was reported (the forecaster's own chance of this, stated with the estimate: 35%); the middle value does not contradict the limit.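

Compound 3 is recorded only as a limit of the assay and not as a number: the limit of > 10 nM in this assay, at which 1 of the 3 values shown sits.

Even so, this gives the first reading of a change at this position, on a saturated chain carbon, two bonds along the chain from an oxygen on an aromatic ring. In this assay, from the compounds shown here alone, the exchange of piperidin-4-yl for chloromethyl, which turns the 2-(piperidin-4-yl)ethoxy tail into a 3-chloropropoxy tail, amounts to an at least 7.5-fold higher number from compound 2 to compound 3 (0.87 log units; beyond the scatter), so what stands at this place is not a matter of indifference to the result, although the full size of the loss stays unknown while compound 3 has only a limit.

Within the data shown here, the single step cannot tell whether the loss follows the ring, its nitrogen or the chlorine that enters, and a cyclohexyl end, which keeps the ring without the nitrogen, or an open-chain primary amine, which keeps the nitrogen without the ring, would pull these apart. The compounds shown also leave open how a longer chain between the oxygen and the piperidin-4-yl would read in this assay.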